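This account rests on a few compounds, and the source may have more. Where it says the series, first, only, none or still open, it means among the compounds named here.

Of the compounds shown here, two have been measured in an assay on isolated protein for inhibition of Dihydrofolate reductase (Homo sapiens); a lower number here means a stronger inhibitor, a higher number a weaker inhibitor. Compound 1 (`CCc1nc(N)nc(N)c1C#CC(C)c1cc(OC)cc(-c2cccc3cnccc23)c1`) gives 45 nM. For the measured compounds named here, compound 2 (`CCc1nc(N)nc(N)c1C#CCc1cc(OC)cc(-c2ccc3c(c2)OCCO3)c1`) gives 140 nM, the higher of the two numbers; the gap to compound 1 is beyond the scatter, but the two structures differ in more than one place, so the two values show only that compound 2 is the weaker inhibitor here.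

Compound 3 (`CCc1nc(N)nc(N)c1C#CC(C)c1cc(OC)cc(-c2ccc3c(c2)OCCO3)c1`) is the next step from compound 2: methyl in place of hydrogen on a saturated chain carbon bound to an aromatic carbon and a triple-bonded carbon. Going by the values given here, no single-change step of this kind has been measured, so the direction must be guessed. Compound 1 carries the same methyl on that carbon and gives 45 nM, which points loosely toward a lower number, though its different aryl group confounds the comparison. A modest gain is expected, as an estimated step of a 1.8-fold lower number from compound 2 to compound 3 (0.24 log units; within the scatter) in this assay. Compound 3 is therefore expected to give about 80 nM, with a likely range of 30 nM to 250 nM.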

Compound 3, half-maximal inhibitory concentration: 260 nM
Estimate against measurement, compound 3: 3.3-fold (0.51 log units) below; measured number above the stated range.
By their numbers in this assay, from the lowest: compound 1; then compounds 2 and 3 (each within the scatter of the next).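

In this assay, methyl in place of hydrogen on a saturated chain carbon bound to an aromatic carbon and a triple-bonded carbon gives a 1.9-fold higher number from compound 2 to compound 3 (0.27 log units; within the scatter), so with 2,3-dihydro-1,4-benzodioxin-6-yl on the aromatic carbon, this single-place change is not separated from the scatter. With the methyl held constant, 2,3-dihydro-1,4-benzodioxin-6-yl in place of isoquinolin-5-yl on an aromatic carbon gives a 5.8-fold higher number from compound 1 to compound 3 (0.76 log units; beyond the scatter), and of the two steps only this one lies beyond the scatter. Nothing available explains the size of either step.

The compounds shown leave open whether methyl in place of hydrogen on that chain carbon reads the same with isoquinolin-5-yl on the aromatic carbon. They also leave open whether a larger ethyl or a hydroxyl on that carbon would give a step beyond the scatter.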